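Benzyl-tetrazolyl for nitrile on the biaryl of compound 2

This account rests on a few compounds, and the source may have more. Where it says the series, first, only, none or still open, it means among the compounds named here.

Compound 1 `Cc1ccccc1-c1ccc(CN2C(=O)[C@H](NC(=O)CC(C)(C)N)CCc3ccccc32)cc1` and compound 2 `CC(C)(N)CC(=O)N[C@@H]1CCc2ccccc2N(Cc2ccc(-c3ccccc3C#N)cc2)C1=O` share one core and differ only at the outer aromatic ring. In a functional assay (Pituitary gland cell) with Rattus norvegicus as the target (on this read-out higher numbers stand for an effect only at larger amounts of compound and lower numbers for an effect already at smaller amounts), compound 1 gives 1 uM, while compound 2 gives 5 uM. Among the measured compounds shown here, the single step measured so far, a 5.0-fold higher number from compound 1 to compound 2 (0.70 log units; beyond the scatter), was cyano in place of methyl on an aromatic carbon. On the numbers shown, compound 2 stands as the highest of the two, with compound 1 the nearest.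

Compound 3 `CC(C)(N)CC(=O)N[C@@H]1CCc2ccccc2N(Cc2ccc(-c3ccccc3-c3nnn(Cc4ccccc4)n3)cc2)C1=O` is the next step: 2-benzyl-2H-tetrazol-5-yl in place of cyano on an aromatic carbon. The change sits on an aromatic carbon of a six-membered aromatic ring of carbon only, ortho to a large group. For the measured compounds named here, the measured step concerned only the exchange of methyl for cyano and says nothing about replacing cyano with a much larger group; no step bears directly on this change. The expectation for this assay is therefore a step of uncertain direction and no clear size beyond the scatter, a 1.2-fold higher number from compound 2 to compound 3 (0.08 log units; within the scatter). Compound 3 is estimated at 6 uM, within a range from 1.5 uM to 25 uM.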

Compound 3, concentration for half-maximal effect: 1 uM
Compound 3: middle estimate off by 6.0-fold (0.78 log units), on the high side; measured number outside the range, below it.
By their numbers in this assay, from the lowest: compounds 1 and 3 (each within the scatter of the next); then compound 2.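

At this aromatic carbon, ortho to a large group, the series accepts a far larger substituent than methyl or cyano: in this assay replacing cyano with 2-benzyl-2H-tetrazol-5-yl gives a 5.0-fold lower number from compound 2 to compound 3 (0.70 log units; beyond the scatter) and so reverses the loss seen with cyano. Against methyl, the same exchange gives no change at the digits printed from compound 1 to compound 3 (within the scatter) even though the entering group has 12 heavy atoms and two aromatic rings, so across these three compounds the read-out does not follow the size of the group at this position. No measured information bears on why the nitrile stands apart from the other two groups here.

As far as these compounds go, whether the step from compound 2 to compound 3 belongs to the tetrazole ring or to the benzyl group on it remains open, and a 2H-tetrazol-5-yl without the benzyl group or a carboxylic acid on the same carbon would help separate the two. From the compounds shown here alone, it is also open whether a group of intermediate size, such as a phenyl ring or an aminomethyl group, would fall with methyl and 2-benzyl-2H-tetrazol-5-yl or with cyano.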